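Saturating the Linker and Swapping Methoxy for Fluoro

The compounds below may be only part of what the source reports. "The series", "measured", "known", "first", "only" and "open" are said of these compounds alone.

Compound 2 `COc1ccc(/C=C/c2nc(N3CCC(CCNS(N)(=O)=O)CC3)c3cc(OC)c(OC)cc3n2)cc1` gives the lowest of the two numbers shown in an assay on cells for inhibition of Ectonucleotide pyrophosphatase/phosphodiesterase family member 1 (Homo sapiens), with a stated time of 60 min (on this read-out lower numbers stand for stronger inhibition and higher numbers for weaker inhibition), namely 231 nM; compound 1 `COc1cc2nc(/C=C/c3ccc(F)cc3)nc(N3CCC(CCNS(N)(=O)=O)CC3)c2cc1OC` gives 465 nM, and the step of a 2.0-fold lower number from compound 1 to compound 2 (0.30 log units; within the scatter) stays within the scatter. Compound 3 `COc1cc2nc(CCc3ccc(F)cc3)nc(N3CCC(CCNS(N)(=O)=O)CC3)c2cc1OC` takes the next step: 2-(4-fluorophenyl)ethyl in place of 2-(4-methoxyphenyl)ethenyl on an aromatic carbon. Only the methoxy-for-fluoro exchange has been measured, and that step lay within the scatter, so reversing it is expected to give a somewhat higher number, while nothing measured bears on the loss of the double bond. Compound 3 is therefore expected at 700 nM, between 250 nM and 2500 nM, an estimated step of a 3.0-fold higher number from compound 2 to compound 3 (0.48 log units; beyond the scatter).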

Compound 3, inhibition constant: 366 nM
For compound 3 the middle estimate is 1.9-fold (0.28 log units) above the measured one; the range from low to high includes it.
By their numbers in this assay, from the lowest: compounds 2, 3 and 1 (each within the scatter of the next).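

The cleanest reading here is the exchange of 2-(4-fluorophenyl)ethenyl for 2-(4-fluorophenyl)ethyl, which changes only the double bond and gives a 1.3-fold lower number from compound 1 to compound 3 (0.10 log units; within the scatter) in this assay. Within this pair, then, losing the double bond moves the number no further than the scatter. The larger exchange, which also replaces methoxy with fluoro, gives a 1.6-fold higher number from compound 2 to compound 3 (0.20 log units; within the scatter), so it too stays within the scatter. Nothing available explains why these numbers lie so close. Still open, going by these compounds, is how this position responds to a longer chain than 2-(4-fluorophenyl)ethyl, or to an amine or a carboxylic acid on the aromatic ring in place of fluoro or methoxy.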